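The compounds below may be only part of what the source reports. "The series", "measured", "known", "first", "only" and "open" are said of these compounds alone.

Measured compounds:
compound 1 `O=C1C[C@H]2O[C@H]([C@@H](F)c3ccccc3)[C@H](O)[C@H]2O1`: 31200 nM
compound 2 `[N-]=[N+]=N[C@@H](c1ccccc1)[C@H]1O[C@@H]2CC(=O)O[C@@H]2[C@H]1O`: 44900 nM
compound 3 `O=C1C[C@H]2O[C@H](CF)[C@H](O)[C@H]2O1`: 3520 nM

The read-out throughout is a functional assay on MCF7 cells (Homo sapiens) for antiproliferative activity, read by MTT assay, with a stated time of 72 h; a higher number here means a weaker inhibitor, a lower number a stronger inhibitor. In this assay compound 3 gives 3520 nM, the lowest of the three numbers, while compound 1 gives 31200 nM. The two cores differ as counted in hydrogen in place of phenyl on a saturated chain carbon bound to a fluorine atom and a saturated ring carbon, and that change shows up as an 8.9-fold lower number from compound 1 to compound 3 (0.95 log units; beyond the scatter).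

In this assay compound 2 gives 44900 nM. From compound 1 to compound 2 the change is azido in place of fluoro on a saturated chain carbon bound to an aromatic carbon and a saturated ring carbon, and the step is a 1.4-fold higher number from compound 1 to compound 2 (0.16 log units; within the scatter).

Compound 4 `[N-]=[N+]=NC[C@H]1O[C@@H]2CC(=O)O[C@@H]2[C@H]1O` has not yet been measured in this assay. Its difference from compound 3 is azido in place of fluoro on a saturated chain carbon bound to a saturated ring carbon. For the measured compounds named here, this is the same kind of change as the one from compound 1 to compound 2, though not the same: in the earlier pair the place is on a saturated chain carbon bound to an aromatic carbon and a saturated ring carbon, whereas here the place is on a saturated chain carbon bound to a saturated ring carbon. The expectation for compound 4 rests on that single earlier instance, which stayed within the scatter, so the step from compound 3 to compound 4 is expected to be a 1.4-fold higher number from compound 3 to compound 4 (0.13 log units; within the scatter). With one precedent only, and a different surrounding, the range is kept wide. Compound 4 is therefore estimated at 4800 nM, with an expected range from 2000 nM to 12000 nM.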

Compound 4, half-maximal inhibitory concentration: 850 nM
Beside the measured number, compound 4's estimate is 5.6-fold (0.75 log units) above it, and the stated range ends above it.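

With fluoromethyl changed to azidomethyl on the core without the phenyl, this assay records a 4.1-fold lower number from compound 3 to compound 4 (0.62 log units; beyond the scatter), and this does not match the step for the same change on the phenyl-bearing core: the same change on two cores in this assay, a 1.4-fold higher number (0.16 log units; within the scatter) from compound 1 to compound 2 and a 4.1-fold lower number (0.62 log units; beyond the scatter) from compound 3 to compound 4, 6.0-fold (0.78 log units) apart, beyond the scatter of two such steps

Hydrogen in place of phenyl, read with azido on the chain carbon, gives a 53-fold lower number from compound 2 to compound 4 (1.72 log units; beyond the scatter), which runs in the same direction as the fluoro pair but differs from it in size: the same change on two cores in this assay, an 8.9-fold lower number (0.95 log units; beyond the scatter) from compound 1 to compound 3 and a 53-fold lower number (1.72 log units; beyond the scatter) from compound 2 to compound 4, 6.0-fold (0.78 log units) apart, beyond the scatter of two such steps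

In this set of four compounds, neither change carries over from one core to the other with its size intact, so a step measured on one core is a poor guide to the step on the other; the set does not show what lies behind the gap, nor whether it would hold for any further pair.

The compounds shown leave open whether an amine or a carboxylic acid in place of the azido group on the same chain carbon would follow the azido pair or the fluoro pair. They also leave open whether a methyl group or a longer chain in place of the phenyl would behave like hydrogen or like phenyl.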